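Methoxycarbonyl added to the core of compound 1

A few compounds are considered here, and "the series" means these few. Any claim that something is new, unique, unknown or untested is made for them only; others in the source may bear on it.

Measured in a functional assay on NCI-H1299 cells (Homo sapiens) for antiproliferative activity, read by CCK-8 assay, with a stated time of 72 h (a higher number here means a weaker inhibitor, a lower number a stronger inhibitor), so far:
- compound 1 `Nc1ccccc1NC(=O)c1ccc(CSC(=S)N2CCc3ccccc32)cc1` gives 2900 nM
- compound 2 `CCN(Cc1ccncc1)C(=S)SCc1ccc(C(=O)Nc2ccccc2N)cc1` gives 750 nM
- compound 3 `Nc1ccccc1NC(=O)c1ccc(CSC(=S)N2CCN(c3ccncc3)CC2)cc1` gives 2490 nM

Compound 1 at 2900 nM lies within the scatter of compound 3 at 2490 nM and has compound 2 clearly below it. That gap is a 3.9-fold lower number from compound 1 to compound 2 (0.59 log units; beyond the scatter) with ethyl((pyridin-4-yl)methyl)amino in place of 2,3-dihydro-1H-indol-1-yl on a thiocarbonyl carbon.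

Compound 4 `COC(=O)c1ccc2c(c1)CCN2C(=S)SCc1ccc(C(=O)Nc2ccccc2N)cc1` differs from compound 1 by methoxycarbonyl in place of hydrogen on an aromatic carbon in the form of methoxycarbonyl in place of hydrogen on an aromatic carbon. Among the compounds with values here, the one measured step exchanges the group on the thiocarbonyl carbon, and no measured pair tests a substituent on this aromatic carbon, so that step sets only a loose scale. In this assay, on these data alone, no step beyond the scatter is expected, and the direction stays open. The estimated change is a 1.2-fold lower number from compound 1 to compound 4 (0.08 log units; within the scatter) as a working figure. For compound 4 the expected value is 2400 nM with an estimated range from 700 nM to 7000 nM for now.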

Compound 4, half-maximal inhibitory concentration: 2020 nM
Compound 4: middle estimate off by 1.2-fold (0.07 log units), on the high side; measured number inside the range.
By their numbers in this assay, from the lowest: compound 2; then compounds 4, 3 and 1 (each within the scatter of the next).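

In this assay, methoxycarbonyl in place of hydrogen gives the first measured result for this aromatic carbon, meta to a fused ring and para to a fused ring: a 1.4-fold lower number from compound 1 to compound 4 (0.16 log units; within the scatter). This position of the core of compound 1 therefore carries methoxycarbonyl with no step beyond the scatter, whereas the exchange of the whole group on the thiocarbonyl carbon gives a 3.9-fold lower number from compound 1 to compound 2 (0.59 log units; beyond the scatter). Nothing available bears on why the ester leaves the number within the scatter.

On these data alone, a single substituent cannot show whether this tolerance is general, so it remains open whether a carboxylic acid, an amine or a longer alkyl ester on this aromatic carbon would also stay within the scatter. Also open, as far as these compounds go, is whether methoxycarbonyl gives a similar result on the other aromatic carbons of the same ring.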